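The source may report more compounds than this note shows. Statements on the series, on what has been measured and on what is new or still open speak of the compounds shown alone.

In a functional assay on Huh-7 cells (Homo sapiens) for antiproliferative activity, read by CCK-8 assay, with a stated time of 72 h (a lower number here means a stronger inhibitor of growth, a higher number a weaker inhibitor of growth), compound 2 `CC[C@@H]1C(=O)N(C)c2cnc(Nc3ccc(S(=O)(=O)NCCCO)cc3)nc2N1C1CCCC1` gives 262 nM and compound 1 `CCCCNS(=O)(=O)c1ccc(Nc2ncc3c(n2)N(C2CCCC2)[C@H](CC)C(=O)N3C)cc1` gives 225 nM, so the two lie within the scatter of each other. Compound 3 `CC[C@@H]1C(=O)N(C)c2cnc(Nc3ccc(S(=O)(=O)NCC(C)C)cc3)nc2N1C1CCCC1` is still unmeasured. Its difference from compound 2 is isopropyl in place of 2-hydroxyethyl on a saturated chain carbon bound to a sulfonamide nitrogen, or 3-hydroxypropyl to isobutyl when cut one bond further out. Within the data shown here, only one measured step bears on this: hydroxy in place of methyl on a saturated chain carbon, three bonds along the chain from a sulfonamide nitrogen. Compound 3, like compound 1, has no hydroxy on that chain. No change beyond the scatter is expected in this assay because a 1.2-fold higher number from compound 1 to compound 2 (0.07 log units; within the scatter). One step is thin support, and the branching itself has not been tested. Compound 3 is estimated at 240 nM, with an expected range of 110 nM to 520 nM. The expected step is a 1.1-fold lower number from compound 2 to compound 3 (0.04 log units; within the scatter).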

Compound 3, concentration for 50% growth inhibition: 411 nM
Compound 3: the middle estimate sits 1.7-fold (0.23 log units) below what was measured; low and high end bracket the measured number.
By their numbers in this assay, from the lowest: compounds 1, 2 and 3 (each within the scatter of the next).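

On the saturated chain carbon bound to a sulfonamide nitrogen, this assay gives a 1.6-fold higher number from compound 2 to compound 3 (0.20 log units; within the scatter) for isopropyl in place of 2-hydroxyethyl. The same place gives a 1.8-fold higher number from compound 1 to compound 3 (0.26 log units; within the scatter) for isopropyl in place of propyl and so adds the first branched chain to the comparison, and neither step leaves the scatter, so compounds 1, 2 and 3 do not separate on branching or on the hydroxy group. Nothing available here explains these numbers.

Going by these compounds, whether an amine, a carboxylic acid or a longer chain in this place would move the number beyond the scatter remains open. Also open, on these data alone, is whether the three chains stay this close with any other change to the shared core.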